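Methoxy in Place of Isopropyl: What Potency to Expect

The compounds below may be only part of what the source reports. "The series", "measured", "known", "first", "only" and "open" are said of these compounds alone.

Measured compounds:
Compound 1, `CCc1nc(SC)c2n1CCN([C@@H](C(=O)NC)c1ccccc1)[C@H]2CCc1ccc(C(F)(F)F)cc1`, gives 14 nM in a functional assay on CHO cells for antagonist activity at Orexin receptor type 2 (Homo sapiens), read by FLIPR and calcium flux; a higher number here means a weaker inhibitor, a lower number a stronger inhibitor.
Compound 2, `CCc1nc(C(C)C)c2n1CCN([C@@H](C(=O)NC)c1ccccc1)C2CCc1ccc(C(F)(F)F)cc1`, gives 2900 nM in this assay.
Compound 3, `CNC(=O)[C@@H](c1ccccc1)N1CCn2c(C)nc(Cl)c2[C@@H]1CCc1ccc(C(F)(F)F)cc1`, gives 13 nM in this assay.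

Among the three, compound 2 stands highest in this assay, which marks it as the weakest inhibitor of the set. Both compound 1 and compound 3 sit far lower, each beyond the usual scatter. Compound 2 differs from the other two in what it carries on the aromatic carbon of the five-membered ring: an isopropyl, where compound 1 carries a methylthio and compound 3 a chloro.

Compound 4, `CCc1nc(OC)c2n1CCN([C@@H](C(=O)NC)c1ccccc1)C2CCc1ccc(C(F)(F)F)cc1`, has not yet been measured. It differs from compound 2 by methoxy in place of isopropyl on an aromatic carbon. Within the data shown here, no measured pair isolates this change, so the expectation rests on the three numbers alone. Compound 4 is expected to fall well below compound 2, a step of a 58-fold lower number from compound 2 to compound 4 (1.76 log units; beyond the scatter), because compound 1 without an isopropyl at this carbon gives 14 nM and compound 3 without it gives 13 nM, both far lower. Compound 4 is therefore estimated at 50 nM, within 8 nM to 300 nM.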

Compound 4, half-maximal inhibitory concentration: 73 nM
Beside the measured number, compound 4's estimate is 1.5-fold (0.16 log units) below it, and the stated range covers the measured number.
By their numbers in this assay, from the lowest: compounds 3 and 1 (each within the scatter of the next); then compound 4; then compound 2.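

With the rest of the structure unchanged, methoxy in place of isopropyl on this aromatic carbon gives a 40-fold lower number from compound 2 to compound 4 (1.60 log units; beyond the scatter) in this assay, so this single change is enough to produce a large shift in the number. The earlier compounds shown here could only hint at this, as compound 1 and compound 3 each differ from compound 2 in more than one place. Nothing shown here gives a measured reason for the shift.

Going by these compounds, it remains open whether the shift depends on the oxygen that methoxy brings or on the removal of isopropyl. An ethoxy, a cyclopropyl or an amine on the same carbon, with the ethyl group and the rest of compound 4 kept, would help to separate these two readings.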